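A few compounds are considered here, and "the series" means these few. Any claim that something is new, unique, unknown or untested is made for them only; others in the source may bear on it.

Compound 1 `CC1(C)[C@H]2CC[C@]1(C)N(Cc1cn(-c3ccccc3F)nn1)C(=O)C2` gives 5260 nM in an ADME assay on NCM460 cells (Homo sapiens) for cytotoxicity, read by MTT assay, with a stated time of 24 h; a lower number here means that less compound is tolerated, a higher number that more compound is tolerated. Compound 2 `CC1(C)[C@H]2CC[C@]1(C)N(Cc1cn(-c3cccc(Cl)c3)nn1)C(=O)C2` gives 8410 nM.

Of these two numbers, that of compound 2 is nominally the higher, yet the step of a 1.6-fold higher number from compound 1 to compound 2 (0.20 log units; within the scatter) lies within the scatter, so the two compounds cannot be told apart. Compound 3 `CC1(C)[C@H]2CC[C@]1(C)N(Cc1cn(-c3cccc(Br)c3)nn1)C(=O)C2` differs from compound 2 by bromo in place of chloro on an aromatic carbon. Within the data shown here, the only measured step, a 1.6-fold higher number from compound 1 to compound 2 (0.20 log units; within the scatter), exchanged the whole halophenyl group and still stayed within the scatter, which gives no ground for a change beyond the scatter here. A shift of a 1.1-fold lower number from compound 2 to compound 3 (0.05 log units; within the scatter) is therefore expected. Compound 3 is estimated at 7500 nM, within a range from 3500 nM to 16000 nM.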

Compound 3, half-maximal cytotoxic concentration: 14600 nM
The estimate for compound 3 lay 1.9-fold (0.29 log units) below the measured number, within the range that was stated.
By their numbers in this assay, from the lowest: compounds 1, 2 and 3 (each within the scatter of the next, the first and the last beyond it).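

Bromo in place of chloro on this aromatic carbon gives a 1.7-fold higher number from compound 2 to compound 3 (0.24 log units; within the scatter), so these two halogens cannot be told apart in this assay. Across the halophenyl exchange, the change gives a 2.8-fold higher number from compound 1 to compound 3 (0.44 log units; beyond the scatter), a modest step and the first here to pass the scatter, though the halogen and its place on the ring both differ, so the step cannot be credited to either alone. No measurement shown explains these numbers. As far as these compounds go, whether an amine or a carboxylic acid in place of the bromo would shift the number remains open.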